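The source may report more compounds than this note shows. Statements on the series, on what has been measured and on what is new or still open speak of the compounds shown alone.

Series notes on cytotoxicity. Going by the values given here, compound 1 `N#Cc1c(-c2c[nH]c3ccccc23)cc(-c2ccc3c(c2)CCCC3)[nH]c1=O` is the first member with a value here. In an ADME assay on RAW264.7 cells (Mus musculus) for cytotoxicity, with a stated time of 24 h (a lower number here means a stronger inhibitor, a higher number a weaker inhibitor), compound 1 gives only > 100000 nM, which is a limit of the assay rather than a number. Compound 2 `COc1ccc(-c2cc(-c3ccc4c(c3)CCCC4)nc3[nH]nc(N)c23)cc1OC` is the nearer relative of the compound still to be made. In this assay compound 2 likewise reports only a limit, > 50000 nM. Among the compounds with values here, compound 2 therefore stands at a limit, and the only other value shown is a limit as well; no finished number exists anywhere in the set, and no step between measured compounds can be sized. Compound 3 `CC(C)c1ccc(-c2cc(-c3ccc4c(c3)CCCC4)nc3[nH]nc(N)c23)cc1` differs from compound 2 in one place: 4-isopropylphenyl in place of 3,4-dimethoxyphenyl on an aromatic carbon. With both shown values sitting at limits (the limit of > 100000 nM in this assay, at which 1 of the 2 values shown sits, (the limit of > 50000 nM in this assay, at which 1 of the 2 values shown sits)), there is no measured step to guide the size or direction of the change; the expectation is no step beyond the scatter, and compound 3 is expected to remain at a limit. The expected step is a step that the limit leaves unreadable from compound 2 to compound 3. For compound 3 the estimate in this assay is 60000 nM, with a range from 20000 nM to 150000 nM.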

Compound 3, half-maximal inhibitory concentration: > 50000 nM
Compound 3: only a limit was reported (the forecaster's own chance of this, stated with the estimate: 75%); the middle value does not contradict the limit.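

In this assay compound 3 gives > 50000 nM, a limit of the assay and not a number. Going by these compounds alone, compound 2 also stands at a limit, so no step between compound 2 and compound 3 can be read. The compounds shown leave open whether 4-isopropylphenyl in place of 3,4-dimethoxyphenyl shifts the read-out, and at what concentration any of them reaches half-maximal inhibition.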